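The source may report more compounds than this note shows. Statements on the series, on what has been measured and on what is new or still open speak of the compounds shown alone.

The study sets four nucleoside-like compounds side by side in a toxicity assay on Huh-7 cells (Homo sapiens) for cytotoxicity, with a stated time of 3 days; on this read-out higher numbers stand for lower toxicity in this test and lower numbers for higher toxicity in this test. Compound 1 `C[C@@]1(O)[C@H](O)[C@@H](CO)O[C@H]1n1cc(-c2ccoc2)c2c(N)ncnc21` carries a furan-3-yl group on its core. In this assay compound 1 gives > 44000 nM, which is a limit of the assay and not a number. Compound 2 `C[C@@]1(O)[C@H](O)[C@@H](CO)O[C@H]1n1cc(-c2ccsc2)c2c(N)ncnc21` differs from compound 1 by thiophen-3-yl in place of furan-3-yl on an aromatic carbon. In this assay compound 2 gives > 44000 nM, again a limit. The step that the two limits leave unreadable from compound 1 to compound 2 therefore cannot be sized from these two results. Compound 3 `Nc1ncnc2c1c(-c1ccoc1)cn2[C@H]1C[C@H](O)[C@@H](CO)O1` is built on a different core; the difference between the two cores is not broken down here. In this assay compound 3 gives > 44000 nM, also a limit.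

Compound 4 `Nc1ncnc2c1c(-c1ccsc1)cn2[C@H]1C[C@H](O)[C@@H](CO)O1` has not yet been measured and differs from compound 3 by thiophen-3-yl in place of furan-3-yl on an aromatic carbon. Within the data shown here, this is the same kind of change as the one that turns compound 1 into compound 2; the surroundings are described in one case as a ring atom that bears a group of 8 heavy atoms and in the other as a ring atom that bears a large group. Because the limit of > 44000 nM in this assay, at which 3 of the 3 values shown sit, gathers every measured result at the same boundary, no readable step is available to carry over. The expected step is a step that the limit leaves unreadable from compound 3 to compound 4, essentially none. Compound 4 is accordingly estimated at 70000 nM, with a likely range from 30000 nM to 200000 nM, and the assay is expected most probably to report only a limit for it once more.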

Compound 4, half-maximal cytotoxic concentration: > 44000 nM
Compound 4 ended at the assay's limit; the forecaster's own chance of this, stated with the estimate: 85%; the middle value is on the limit's open side.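

No step can be read from compound 3 to compound 4, nor from compound 1 to compound 2, since all four results in this assay are limits and not numbers: the limit of > 44000 nM in this assay, at which 4 of the 4 values shown sit. The compounds shown leave open how far the toxicity of each lies past that limit, and whether thiophen-3-yl in place of furan-3-yl changes it at all.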